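Chloro substitution on the anilino ring of a thiazolyl chalcone

The compounds below may be only part of what the source reports. "The series", "measured", "known", "first", "only" and "open" are said of these compounds alone.

Of the compounds shown here, three of one family have been measured. Compound 1 `COc1cccc(/C=C/C(=O)c2sc(Nc3ccc(Cl)cc3)nc2C)c1`, compound 2 `COc1cccc(/C=C/C(=O)c2sc(Nc3ccccc3)nc2C)c1` and compound 3 `Cc1nc(Nc2cccc(Cl)c2)sc1C(=O)/C=C/c1ccccc1` share a core; how the core of compound 3 differs from that of compound 2 is not broken down here. In a functional assay on NCI-H460 cells (Homo sapiens) for cytotoxicity, read by MTT assay (on this read-out lower numbers stand for stronger inhibition and higher numbers for weaker inhibition), compound 1 gives > 25000 nM, which is a limit of the assay and not a number. In this assay compound 2 gives > 25000 nM, likewise a limit. Compound 3 gives > 25000 nM in this assay, again a limit.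

The change from compound 2 to compound 1 is chloro in place of hydrogen on an aromatic carbon. Its step is a step that the two limits leave unreadable from compound 2 to compound 1, and it cannot be read because of the limit of > 25000 nM in this assay, at which 3 of the 3 values shown sit.

Compound 4 `Cc1nc(Nc2ccc(Cl)c(Cl)c2)sc1C(=O)/C=C/c1ccccc1` has not yet been measured. It differs from compound 3 by chloro in place of hydrogen on an aromatic carbon. This is the same kind of change as that from compound 2 to compound 1, but the place is not the same: in compound 4 the entering group sits ortho to a chloro group (1 heavy atom) and para to a large group, whereas in compound 1 it sits only para to a large group.

Among the compounds with values here, since the one measured example of this kind of change gives no readable size, and since compound 3 itself sits at the limit > 25000 nM, the step from compound 3 to compound 4 is expected to be about a step that the limit leaves unreadable from compound 3 to compound 4. Compound 4 is therefore estimated at 30000 nM, between 6000 nM and 150000 nM, with the assay most likely again reporting only a limit.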

Compound 4, half-maximal inhibitory concentration: 22700 nM
Compound 4: middle estimate off by 1.3-fold (0.12 log units), on the high side, within the range that was stated.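

In this assay, within the data shown here, chloro in place of hydrogen, taking 3-chlorophenyl to 3,4-dichlorophenyl, gives the one readable step of this kind, an at least 1.1-fold lower number from compound 3 to compound 4 (0.04 log units; that floor lies within the scatter). Among these compounds, compound 3 gives > 25000 nM, which is a limit and not a number, so the true size of this step stays unknown and the floor shows only that compound 4 yields a number. The same kind of change from compound 2 to compound 1 cannot be read, and the entering chloro also sits in a different place, ortho to a chloro group and para to a large group in compound 4 but only para to a large group in compound 1, so the result shows no transfer of the change from one core to the other, and no size can be compared because of the shared limit: the limit of > 25000 nM in this assay, at which 3 of the 4 values shown sit.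

The compounds shown leave open how the same place on the ring would respond to a group other than chloro, such as an amine or a carboxylic acid. They also leave open whether a 3,4-dichlorophenyl group on the core of compound 1 would give a number rather than a limit.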